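From 4-ethylphenyl to 3,5-dichlorophenyl on the shared core

The source may hold more compounds than are shown below. What is called first, only, known or untested is meant among the compounds shown, and "the series" means these compounds.

Compound 1 `O=C1C(Nc2ccc(-c3ccc(Cl)cc3)cc2)=CC(=O)c2ncncc21` gives 4400 nM
Compound 2 `O=C1C(Nc2ccc(C3CCCCC3)cc2)=CC(=O)c2ncncc21` gives 900 nM
Compound 3 `CCc1ccc(-c2ccc(NC3=CC(=O)c4ncncc4C3=O)cc2)cc1` gives 2300 nM

In a functional assay on PANC-1 cells (Homo sapiens) for cytotoxicity, read by MTT assay, with a stated time of 72 h (a lower number here means a stronger inhibitor, a higher number a weaker inhibitor), compound 3 gives 2300 nM and stands close to compound 1 but apart from compound 2. The steps into it are a 1.9-fold lower number from compound 1 to compound 3 (0.28 log units; within the scatter) and a 2.6-fold higher number from compound 2 to compound 3 (0.41 log units; beyond the scatter) here. Compound 4 `O=C1C(Nc2ccc(-c3cc(Cl)cc(Cl)c3)cc2)=CC(=O)c2ncncc21` has 3,5-dichlorophenyl in place of 4-ethylphenyl on an aromatic carbon. The closest guide is compound 1, which carries 4-chlorophenyl and gives 4400 nM in this assay. Among the measured compounds shown here, the cyclohexyl step a 4.9-fold lower number from compound 1 to compound 2 (0.69 log units; beyond the scatter) says less, and no measured compound has two chloro groups. A small rise is therefore expected, perhaps none beyond the scatter. The estimated move is a 1.3-fold higher number from compound 3 to compound 4 (0.12 log units; within the scatter) overall. Compound 4 is expected near 3000 nM with an estimated range of 1200 nM to 7000 nM in this assay.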

Compound 4, half-maximal inhibitory concentration: 1900 nM
Compound 4: middle estimate off by 1.6-fold (0.20 log units), on the high side, within the range that was stated.
By their numbers in this assay, from the lowest: compound 2; then compounds 4, 3 and 1 (each within the scatter of the next, the first and the last beyond it).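

Going from one chloro group to two gives a modest change, with a 2.3-fold lower number from compound 1 to compound 4 (0.36 log units; beyond the scatter) when 3,5-dichlorophenyl replaces 4-chlorophenyl. Replacing 4-ethylphenyl gives no real separation, with a 1.2-fold lower number from compound 3 to compound 4 (0.08 log units; within the scatter) at this position, while cyclohexyl still gives the lowest number of the set, with a 2.1-fold higher number from compound 2 to compound 4 (0.32 log units; beyond the scatter) on replacing it with 3,5-dichlorophenyl. No available evidence explains these differences.

Open questions remain about other groups at this position. An amine or a carboxylic acid on the phenyl ring, or a longer chain in place of ethyl, could move the number either way.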